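The source may report more compounds than this note shows. Statements on the series, on what has been measured and on what is new or still open speak of the compounds shown alone.

Measured compounds:
- Compound 1 `N#Cc1ccc(-c2nc(NCCNc3ccc([N+](=O)[O-])c(N)n3)ncc2-c2ncc[nH]2)cc1`. In an ADME assay on microsomes from liver (Rattus norvegicus) for metabolic stability (a lower number here means that the compound disappears faster, a higher number that the compound lasts longer), compound 1 gives > 0.5 h, a limit of the assay.
- Compound 2 `FC(F)(F)c1ccc(NCCNc2ncc(-c3ncc[nH]3)c(-c3ccc(Cl)cc3Cl)n2)nc1`. In this assay compound 2 gives > 0.5 h, again a limit.
- Compound 3 `Nc1nc(NCCNc2ncc(-c3ncc[nH]3)c(-c3ccc(F)cc3Cl)n2)ccc1[N+](=O)[O-]`. In this assay compound 3 gives > 0.5 h, also a limit.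

Compound 3 therefore stands only at a limit, and so do the two other values shown; all three sit at the limit of > 0.5 h in this assay, at which 3 of the 3 values shown sit. Going by the values given here, the one measured step that touches compound 3, a step that the two limits leave unreadable from compound 1 to compound 3, cannot be read, since both ends are limits. Nothing in the measured set distinguishes the aryl groups in this assay.

Compound 4 `Cc1cc(Cl)ccc1-c1nc(NCCNc2ccc([N+](=O)[O-])c(N)n2)ncc1-c1ncc[nH]1` differs from compound 3 by 4-chloro-2-methylphenyl in place of 2-chloro-4-fluorophenyl on an aromatic carbon. This change is of the same kind as the unreadable step above, so no step beyond the scatter can be predicted; the expectation is that compound 4 behaves like compound 3 and again reaches the limit. Compound 4 is estimated at 1 h, in a range from 0.5 h to 3 h. The expected step that the limit leaves unreadable from compound 3 to compound 4 is within the scatter.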

Compound 4, half-life: > 0.5 h
Compound 4: a limit, no number; the forecaster's own chance of this, stated with the estimate: 80%; the middle value does not contradict the limit.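

In this assay compound 4 gives > 0.5 h, a limit. Neither the step from compound 3 to compound 4 nor that from compound 1 to compound 4 can be read, since both ends are limits: the limit of > 0.5 h in this assay, at which 4 of the 4 values shown sit.

The compounds shown leave open what the half-lives actually are and whether the aryl groups differ at all.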